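From 4-Nitrobenzyl to 3-Bromobenzyl on the Shared Core

A few compounds are considered here, and "the series" means these few. Any claim that something is new, unique, unknown or untested is made for them only; others in the source may bear on it.

Of the compounds shown here, three have been measured in a functional assay on PC-9 cells (Homo sapiens) for inhibition, read by MTT assay, with a stated time of 72 h; on this read-out lower numbers stand for stronger inhibition and higher numbers for weaker inhibition. In this read-out, compound 1 `Cc1cc(Nc2cc(-c3cccs3)[nH]n2)n2nc(SCc3ccc(Br)cc3)nc2n1` gives 4890 nM and compound 2 `Cc1cc(Nc2cc(-c3ccccc3)[nH]n2)n2nc(SCc3ccc([N+](=O)[O-])cc3)nc2n1` gives 7980 nM. These two values lie within the scatter of each other, so compound 2 stands level with compound 1 on the numbers available.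

Compound 3 `Cc1cc(Nc2ccn(Cc3ccccc3)n2)n2nc(SCc3ccc(Br)cc3)nc2n1` gives only a limit, > 50000 nM, and not a number.

Compound 4 `Cc1cc(Nc2cc(-c3ccccc3)[nH]n2)n2nc(SCc3cccc(Br)c3)nc2n1` has not yet been measured. Its difference from compound 2 is 3-bromophenyl in place of 4-nitrophenyl on a saturated chain carbon bound to a sulfur. In short, it has 3-bromophenyl in place of 4-nitrophenyl on a saturated chain carbon bound to a sulfur. The group that leaves has 2 hydrogen-bond acceptors, and the group that enters has 0.

Among the compounds with values here, no measured pair of compounds differs in one place only, so the size of this change in this assay has not been observed directly. The expectation rests on the two numbers at hand, compound 1 at 4890 nM and compound 2 at 7980 nM. The estimated step of a 1.2-fold lower number from compound 2 to compound 4 (0.09 log units; within the scatter) is expected to stay within the scatter, with no clear direction. For compound 4 the expected value is 6500 nM, with an estimated range of 2200 nM to 20000 nM.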

Compound 4, half-maximal inhibitory concentration: 8900 nM
For compound 4 the middle estimate is 1.4-fold (0.14 log units) below the measured one; the measured number falls inside the stated range.
By their numbers in this assay, from the lowest: compounds 1, 2 and 4 (each within the scatter of the next). At a limit, above all of these: compound 3.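

In this assay, the exchange of 4-nitrobenzyl for 3-bromobenzyl is now seen directly as a single change on the shared core, and it gives a 1.1-fold higher number from compound 2 to compound 4 (0.05 log units; within the scatter) with everything else in the molecule held the same. The group that leaves has 2 hydrogen-bond acceptors and the group that enters has 0, yet the two compounds stand level, so at this place, on a saturated chain carbon bound to a sulfur, that difference in count comes with no visible difference between these two groups. Nothing measured here speaks to why these two groups read alike.

This one step changes both the substituent on the ring and where it stands, and the compounds shown do not separate those two changes on this core. On these data alone, it also remains open how a plain benzyl, a benzyl carrying an amine or a carboxylic acid, or a longer chain between the sulfur and the ring would read at this place, and whether any such group would move the number beyond the scatter.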